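Series notes: amine substituent on the piperidine of the shared core

The source may hold more compounds than are shown below. What is called first, only, known or untested is meant among the compounds shown, and "the series" means these compounds.

Measured so far:
compound 1, `c1ccc(CNC2CCN(CCCc3c[nH]c4ccc(-n5cnnc5)cc34)CC2)cc1`, 4.6 nM
compound 2, `CC(C)=CCN(C)C1CCN(CCCc2c[nH]c3ccc(-n4cnnc4)cc23)CC1`, 0.5 nM

Both were run in an assay on CHO cells for displacement of a labelled ligand from 5-hydroxytryptamine receptor 1D (Homo sapiens); a higher number here means a weaker inhibitor, a lower number a stronger inhibitor. Compound 2 holds the lowest of the two numbers; its nearest neighbour is compound 1, and the step of a 9.2-fold lower number from compound 1 to compound 2 (0.96 log units; beyond the scatter) was brought about by methyl(3-methylbut-2-en-1-yl)amino in place of benzylamino on a saturated ring carbon.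

Compound 3, `CN(Cc1ccco1)C1CCN(CCCc2c[nH]c3ccc(-n4cnnc4)cc23)CC1`, awaits measurement in this assay. It differs from compound 2 by furan-2-yl in place of 2-methylprop-1-en-1-yl on a saturated chain carbon bound to an amine nitrogen, which brings back an aromatic ring on the amine side chain, as in compound 1, though a smaller one with an oxygen acceptor. Within the data shown here, the only step that bears on this, from compound 1 to compound 2, gave a modest gain when the aromatic ring left, so some of that gain may be returned. For compound 3 the expected step is a 3.0-fold higher number from compound 2 to compound 3 (0.48 log units; beyond the scatter), a move back toward compound 1 without reaching it. The estimate for compound 3 is 1.5 nM, within 0.5 nM to 5 nM.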

Compound 3, half-maximal inhibitory concentration: 9.3 nM
Compound 3: the middle estimate sits 6.2-fold (0.79 log units) below what was measured, outside the stated range (above it).
By their numbers in this assay, from the lowest: compound 2; then compound 1; then compound 3.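

With the methyl on the amine nitrogen held constant, exchanging only the end group on a saturated chain carbon bound to an amine nitrogen gives a 19-fold higher number from compound 2 to compound 3 (1.27 log units; beyond the scatter) in this assay, so this end group alone strongly affects the read-out. The aromatic ring of furan-2-yl does not place the compound between the other two, since the comparison with the benzylamino compound gives a 2.0-fold higher number from compound 1 to compound 3 (0.31 log units; beyond the scatter), although that pair differs in both the ring and the methyl on nitrogen. No supporting measurement accounts for the size of either step.

The compounds shown leave open whether the loss follows the aromatic ring or its oxygen, which thiophen-2-yl and tetrahydrofuran-2-yl at this place would help to separate. A benzyl(methyl)amino group would also isolate the contribution of the nitrogen methyl from that of the ring.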